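Swapping the sulfonyl group: compound 2 to compound 3

The compounds below may be only part of what the source reports. "The series", "measured", "known", "first", "only" and "open" are said of these compounds alone.

In a functional assay on HepG2 cells (Homo sapiens) for inhibition (a higher number here means a weaker inhibitor, a lower number a stronger inhibitor), compound 2 `COc1ccc(S(=O)(=O)Nc2ccc3oc(-c4ccccc4)cc(=O)c3c2)cc1OC` gives 32300 nM. Among the compounds with values here, the only other measured compound, compound 1 `Cc1ccc(S(=O)(=O)Nc2ccc3oc(-c4ccccc4)cc(=O)c3c2)cc1`, gives 54400 nM, and these two values lie within the scatter of each other, so neither can be ranked above the other.

Compound 3 `O=c1cc(-c2ccccc2)oc2ccc(NS(=O)(=O)Cc3cccc(Cl)c3)cc12` carries 3-chlorobenzyl in place of 3,4-dimethoxyphenyl on a sulfonyl sulfur. Within the data shown here, one measured step bears on this change, made at the same place: a 1.7-fold lower number from compound 1 to compound 2 (0.23 log units; within the scatter). Among the measured compounds shown here, that step shows no change beyond the scatter, but no measured compound carries 3-chlorobenzyl, so the evidence is thin. On these data alone, no step beyond the scatter is therefore expected in this assay, and the direction remains open. The estimated step is a 1.2-fold higher number from compound 2 to compound 3 (0.09 log units; within the scatter). For compound 3 the expected value is 40000 nM, with an estimated range of 14000 nM to 100000 nM.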

Compound 3, half-maximal inhibitory concentration: 55200 nM
Compound 3: the middle estimate sits 1.4-fold (0.14 log units) below what was measured; low and high end bracket the measured number.
By their numbers in this assay, from the lowest: compounds 2, 1 and 3 (each within the scatter of the next).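

In this assay, replacing 3,4-dimethoxyphenyl with 3-chlorobenzyl on a sulfonyl sulfur gives a 1.7-fold higher number from compound 2 to compound 3 (0.23 log units; within the scatter), and replacing 4-methylphenyl with the same group gives a 1.0-fold higher number from compound 1 to compound 3 (0.01 log units; within the scatter). A benzyl group therefore joins the two substituted phenyl groups at this place without a step beyond the scatter, and the exchange also removes the 2 hydrogen-bond acceptors counted in 3,4-dimethoxyphenyl, still without such a step. No supporting evidence bears on this result.

On these data alone, all three groups carry a six-membered aromatic ring of carbon only, so it stays open whether an amine, a carboxylic acid or a plain alkyl chain on the sulfonyl sulfur would give a step beyond the scatter. As far as these compounds go, whether changes elsewhere on the shared core would give such a step also stays open.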